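Compound 3 to compound 4: a swapped side group

A few compounds are considered here, and "the series" means these few. Any claim that something is new, unique, unknown or untested is made for them only; others in the source may bear on it.

Measured in a functional assay on MGC-803 cells (Homo sapiens) for cytotoxicity, read by MTT assay, with a stated time of 38 h; a higher number here means a weaker inhibitor, a lower number a stronger inhibitor:
Compound 1 `COc1cc(OC)c2c(=O)c(OCC(=O)N/N=C/c3ccc(C)cc3)c(-c3cc(OC)c(OC)c(OC)c3)oc2c1`: 3510 nM
Compound 2 `COc1cc(OC)c2c(=O)c(OCC(=O)N/N=C/c3ccccc3F)c(-c3cc(OC)c(OC)c(OC)c3)oc2c1`: 2780 nM
Compound 3 `COc1cc(OC)c2c(=O)c(OCCCN3CCCC3)c(-c3cc(OC)c(OC)c(OC)c3)oc2c1`: 32100 nM

Compound 3 has the highest number of the three, which makes it the weakest inhibitor here. Compound 4 `COc1cc(OC)c2c(=O)c(OCC(=O)N/N=C/c3ccco3)c(-c3cc(OC)c(OC)c(OC)c3)oc2c1` is still unmeasured. The change leading to it is a group of 10 heavy atoms (6 carbon, 2 nitrogen, 2 oxygen; one five-membered aromatic ring with 1 hetero atom) in place of a group of 7 heavy atoms (6 carbon, 1 nitrogen; one five-membered non-aromatic ring with 1 hetero atom), on a saturated chain carbon bound to an oxygen on an aromatic ring. The entering group resembles those of compounds 1 and 2, but it carries a five-membered aromatic ring where they carry a six-membered one. Going by the values given here, two steps bear on this: a 9.1-fold higher number from compound 1 to compound 3 (0.96 log units; beyond the scatter) and a 12-fold higher number from compound 2 to compound 3 (1.06 log units; beyond the scatter). Both run opposite to the present change. The two compounds with the closest groups also differ little: a 1.3-fold lower number from compound 1 to compound 2 (0.10 log units; within the scatter). A similar step towards a lower number is therefore expected, estimated as a 9.2-fold lower number from compound 3 to compound 4 (0.96 log units; beyond the scatter). For compound 4 the estimated value is 3500 nM, with an expected range from 1400 nM to 9000 nM.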

Compound 4, half-maximal inhibitory concentration: 6050 nM
For compound 4 the middle estimate is 1.7-fold (0.24 log units) below the measured one; measured number inside the range.
By their numbers in this assay, from the lowest: compounds 2, 1 and 4 (each within the scatter of the next, the first and the last beyond it); then compound 3.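

In this assay, the gain over the 2-(pyrrolidin-1-yl)ethyl group, a 5.3-fold lower number from compound 3 to compound 4 (0.72 log units; beyond the scatter), also holds when the entering group carries a five-membered aromatic ring. On the carbon with a double bond to nitrogen, furan-2-yl gives the first swap there to pass the scatter, a 2.2-fold higher number from compound 2 to compound 4 (0.34 log units; beyond the scatter), while a 1.7-fold higher number from compound 1 to compound 4 (0.24 log units; within the scatter) stays within it. Nothing measured here explains these differences.

From the compounds shown here alone, it remains open whether a thiophen-2-yl or pyridin-2-yl group on that carbon would give a similar number. A morpholine or piperidine ring on the saturated chain might also differ from the pyrrolidine of compound 3.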